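Cytotoxicity series: trifluoromethyl in place of fluoro

The compounds below may be only part of what the source reports. "The series", "measured", "known", "first", "only" and "open" are said of these compounds alone.

Working notes on three analogues sharing one core, followed in an ADME assay on BJ cells (Homo sapiens) for cytotoxicity, read by CellTiter-Glo and resazurin assay, with a stated time of 72 h; on this read-out lower numbers stand for an effect already at smaller amounts and higher numbers for an effect only at larger amounts of compound. Compound 1 `Cc1nnc(-c2cccc(-c3ccc(C(=O)N(Cc4cccc(OCCCCCC(=O)O)c4)C(C)C)cc3)c2)o1` bears a 5-methyl-1,3,4-oxadiazol-2-yl group on an aromatic carbon. In this assay compound 1 gives > 26000 nM, which is a limit of the assay and not a number. Compound 2 `CC(C)N(Cc1cccc(OCCCCCC(=O)O)c1)C(=O)c1ccc(-c2cccc(F)c2)cc1` has fluoro in place of that group. In this assay compound 2 gives > 26000 nM, again a limit and not a number. The step that the two limits leave unreadable from compound 1 to compound 2 is unreadable because of the limit of > 26000 nM in this assay, at which 2 of the 2 values shown sit. So compound 2 stands at the limit, and no measured step in the series carries a readable size.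

Compound 3 `CC(C)N(Cc1cccc(OCCCCCC(=O)O)c1)C(=O)c1ccc(-c2cccc(C(F)(F)F)c2)cc1` differs from compound 2 by trifluoromethyl in place of fluoro on an aromatic carbon. Among the compounds with values here, no measured step bears on this change, so no direction or size can be drawn from the data. Compound 3 is therefore expected to remain at the limit, the estimated step being a step that the limit leaves unreadable from compound 2 to compound 3. The estimated value for compound 3 in this assay is 30000 nM, with a range from 12000 nM to 80000 nM.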

Compound 3, half-maximal effective concentration: > 26000 nM
Compound 3 gave a limit, no number; the forecaster's own chance of this, stated with the estimate: 80%; the middle value is on the limit's open side.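

Compound 3 also gives a limit and not a number, so the steps from compound 1 and compound 2 to compound 3 cannot be read in this assay: the limit of > 26000 nM in this assay, at which 3 of the 3 values shown sit.

The compounds shown leave open how the three groups on the shared core compare and at what concentration any of these compounds would show an effect.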